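From a Cyclopropyl Amide to a Benzamide: Compound 4

This account rests on a few compounds, and the source may have more. Where it says the series, first, only, none or still open, it means among the compounds named here.

Of the compounds shown here, three sharing one core have been measured in a functional assay on A2780 cells (Homo sapiens) for antiproliferative activity, read by fluorescence, with a stated time of 72 h; on this read-out lower numbers stand for stronger inhibition and higher numbers for weaker inhibition. Compound 1 `CN1CCC(C(=O)N2Cc3c(NC(=O)C4CC4)n[nH]c3C2(C)C)CC1` gives 1420 nM, the highest of the three numbers. Compound 2 `CC(C)(C)C(=O)N1Cc2c(NC(=O)c3cccnc3)n[nH]c2C1(C)C` gives 690 nM, and compound 3 `CC(C)(C)C(=O)N1Cc2c(NC(=O)c3ccncc3)n[nH]c2C1(C)C` gives 110 nM. For the measured compounds named here, the only single-point step among the measured compounds is a 6.3-fold lower number from compound 2 to compound 3 (0.80 log units; beyond the scatter). Compound 1 is set apart from compound 2 and compound 3 at two places, so its distance from them cannot be assigned to one change.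

Compound 4 `CN1CCC(C(=O)N2Cc3c(NC(=O)c4ccccc4)n[nH]c3C2(C)C)CC1` differs from compound 1 at one place: phenyl in place of cyclopropyl on a carbonyl carbon. Going by the values given here, no measured step covers this particular change. What the data do show is that the two compounds carrying an aromatic ring on the carbonyl carbon, compound 2 and compound 3, return lower numbers in this assay than compound 1, though each also carries a different group on the other nitrogen. On that basis, a lower number for compound 4 than for compound 1 is expected, but with wide uncertainty, and the expected step is a 3.2-fold lower number from compound 1 to compound 4 (0.50 log units; beyond the scatter). The estimate for compound 4 in this assay is 450 nM, with a range from 150 nM to 1400 nM.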

Compound 4, half-maximal inhibitory concentration: 160 nM
The estimate for compound 4 lay 2.8-fold (0.45 log units) above the measured number; low and high end bracket the measured number.
By their numbers in this assay, from the lowest: compounds 3 and 4 (each within the scatter of the next); then compound 2; then compound 1.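

In this assay, phenyl in place of cyclopropyl on a carbonyl carbon gives an 8.9-fold lower number from compound 1 to compound 4 (0.95 log units; beyond the scatter), the first step among these compounds to test a non-aromatic ring against an aromatic one with the rest of the structure unchanged. For the compounds shown here, the earlier single-place step, a 6.3-fold lower number from compound 2 to compound 3 (0.80 log units; beyond the scatter), compared only two pyridine rings, whereas the new step shows that a six-membered aromatic ring of carbon only can also lower the number relative to cyclopropyl at this place. No measurement is available that would explain the size of this step.

The compounds shown leave open whether the gain requires the ring itself or would also appear with an open chain such as tert-butyl or a longer chain such as benzyl, and whether a phenyl ring carrying an amine, a methoxy group or a carboxylic acid would keep the number of compound 4 at 160 nM. They also leave open how pyridin-4-yl would behave on the carbonyl carbon of compound 4, since compound 3 and compound 4 differ at two places.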